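Swapping methyl for chloro on a hydrazone-linked aromatic ring

The compounds below may be only part of what the source reports. "The series", "measured", "known", "first", "only" and "open" are said of these compounds alone.

Of the compounds shown here, three have been measured in a functional assay, read by spectrophotometry, with a stated time of 15 min, tested at 20 ug/mL; a lower number here means a weaker effect, a higher number a stronger effect of the compound at the concentration tested. Compound 1 `COC(=O)c1cc(-c2csc(N/N=C/c3ccc(Cl)cc3Cl)n2)ccc1OCc1ccccc1` gives 19.2%, a weak effect. Compound 2 `Cc1ccc(-c2csc(N/N=C/c3cccs3)n2)cc1` gives 90.9%, and compound 3 `Fc1ccc(-c2csc(N/N=C/c3ccc(Cl)cc3Cl)n2)cc1` gives 90.7%. Compound 2 thus stands at the top of the three numbers, but its gap to compound 3 lies within the usual scatter of repeated measurements, so the two cannot be told apart; only compound 1 sits clearly beyond the scatter, far lower.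

Compound 4 `Clc1ccc(-c2csc(N/N=C/c3cccs3)n2)cc1` has not yet been measured. It differs from compound 2 in one place: chloro in place of methyl on an aromatic carbon. Among the measured compounds shown here, no pair of measured compounds shows what this exact swap does. The nearest hint is compound 3, whose six-membered ring carries a halogen and which still gives 90.7%, a number essentially the same as that of compound 2. On that basis the change is expected to produce no step beyond the scatter in this assay; the step of a number 1.9 percentage points lower from compound 2 to compound 4 (within the scatter) is expected to be small.

Compound 4 is therefore estimated to give 89% in this assay, with a likely range from 75% to 96%.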

Compound 4, a percentage reported as inhibition, at one concentration (the size of the read-out at that concentration, not a potency): 94.4%
Compound 4: the middle estimate sits 5.4 percentage points below what was measured; the range from low to high includes it.
By their numbers in this assay, from the lowest: compound 1; then compounds 3, 2 and 4 (each within the scatter of the next).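

In this assay, placing chloro in place of methyl on an aromatic carbon, para to a large group, gives a number 3.5 percentage points higher from compound 2 to compound 4 (within the scatter). Among the compounds shown here, this is the first direct reading of this swap, since the earlier compounds offered only an indirect hint from a halogen in a different compound: with the rest of the structure held constant, methyl and chloro cannot be told apart at this position, and the read-out stays high with either group. For the compounds shown here, nothing measured here explains this result, so the data show only that the two groups give matching read-outs at the one concentration tested, not why they do.

Methyl and chloro each add only one heavy atom, so it remains open whether an amine, a carboxylic acid or a longer chain such as butyl at this same position would keep the read-out this high. Also open, going by these compounds, is whether the same swap would leave the read-out unchanged on a different scaffold, such as that of compound 1, which gives 19.2% and has no partner here differing from it in one place.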